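The source may hold more compounds than are shown below. What is called first, only, known or untested is meant among the compounds shown, and "the series" means these compounds.

In a functional assay on A2780 cells (Homo sapiens) for antiproliferative activity, read by MTT assay, with a stated time of 48 h (on this read-out higher numbers stand for weaker inhibition of growth and lower numbers for stronger inhibition of growth), compound 1 `COc1cccc(C2=NN(C(=O)OCc3ccccc3)C(c3cc(OC)c(OC)c(OC)c3)C2)c1` gives > 10000 nM as its reading, and that is a limit of the assay, not a number. Going by the values given here, compound 2 `CCCOC(=O)N1N=C(c2ccc(OC)cc2)CC1c1cc(OC)c(OC)c(OC)c1` gives 11700 nM as the only true number so far, so it cannot yet be ranked against another measured value. Compound 3 `COc1ccc(C2=NN(C(=O)OCc3ccccc3)C(c3cc(OC)c(OC)c(OC)c3)C2)cc1` departs from compound 2 through phenyl in place of ethyl on a saturated chain carbon bound to an oxygen next to a carbonyl group in one place, on a saturated chain carbon bound to an oxygen next to a carbonyl group; the same change reads propoxycarbonyl to benzyloxycarbonyl. Among the compounds with values here, with compound 2 at 11700 nM as the sole anchor and no measured step to size this change, nothing beyond the scatter is expected in this assay in either direction. The estimated step of a 1.0-fold higher number from compound 2 to compound 3 (0.01 log units; within the scatter) is therefore small. For compound 3 the estimated value is 12000 nM with an expected range of 5000 nM to 30000 nM on this read-out.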

Compound 3, concentration for 50% growth inhibition: > 10000 nM
Compound 3 gave a limit, no number (the forecaster's own chance of this, stated with the estimate: 50%); the middle value does not contradict the limit.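

No step can be read from compound 2 to compound 3 or from compound 1 to compound 3, because each pair includes a limit rather than a number: the limit of > 10000 nM in this assay, at which 2 of the 3 values shown sit.

The compounds shown leave open whether propoxycarbonyl to benzyloxycarbonyl, or 3-methoxyphenyl to 4-methoxyphenyl, shifts growth inhibition at all.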